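Moving a halogen on the benzyl group of an HDAC6 hydroxamate

The source may hold more compounds than are shown below. What is called first, only, known or untested is meant among the compounds shown, and "the series" means these compounds.

The measured compounds:
compound 1 `Cc1cccc(CN2CCC(c3noc(COc4ccc(/C=C/C(=O)NO)cc4)n3)CC2)c1` with 73%
compound 2 `O=C(/C=C/c1ccc(OCc2nc(C3CCN(Cc4ccccc4F)CC3)no2)cc1)NO` with 68%
compound 3 `O=C(/C=C/c1ccc(OCc2nc(C3CCN(Cc4cccc(F)c4)CC3)no2)cc1)NO` with 73%

In an assay on isolated protein for inhibition of protein deacetylase HDAC6 (Homo sapiens), read by fluorescence, with a stated time of 1 h, tested at 100 nM (a lower number here means less inhibition, a higher number more inhibition at the concentration tested (going by the name of the read-out)), compound 3 stands level with compound 1, and together the two are the highest of the three numbers; the furthest from compound 3 is compound 2, with a number 5 percentage points higher from compound 2 to compound 3 (within the scatter).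

Compound 4 `O=C(/C=C/c1ccc(OCc2nc(C3CCN(Cc4ccccc4Cl)CC3)no2)cc1)NO` differs from compound 3 in one place: 2-chlorophenyl in place of 3-fluorophenyl on a saturated chain carbon bound to an amine nitrogen in a ring

Going by the values given here, two measured steps bear on this change. The step of a number 5 percentage points higher from compound 2 to compound 3 (within the scatter) concerns the same ring with the same fluorine in a different position, and the step of a number 5 percentage points lower from compound 1 to compound 2 (within the scatter) also ends on a 2-fluorophenyl group; neither leaves the scatter. Among the compounds with values here, no measured pair shows chlorine in place of fluorine. Compound 4 is therefore expected to sit close to compound 3, with a small step of a number 5 percentage points lower from compound 3 to compound 4 (within the scatter) that need not exceed the scatter. The estimate for compound 4 in this assay is 68%, within a range of 55% to 80%.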

Compound 4, a percentage reported as inhibition, at one concentration (the size of the read-out at that concentration, not a potency): 59%
Compound 4: middle estimate off by 9 percentage points, on the high side, and the stated range covers the measured number.
By their numbers in this assay, from the lowest: compounds 4, 2, 1 and 3 (each within the scatter of the next, the first and the last beyond it).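

In this assay, going by these compounds alone, 2-chlorophenyl on the saturated chain carbon bound to the ring amine nitrogen gives the first steps to pass the scatter, a number 14 percentage points lower from compound 3 to compound 4 (beyond the scatter) and a number 14 percentage points lower from compound 1 to compound 4 (beyond the scatter), so this position does respond to the group placed there, though only modestly. Chloro in place of fluoro with the position unchanged, a number 9 percentage points lower from compound 2 to compound 4 (within the scatter), stays within the scatter, so chlorine alone is not separated from fluorine, and the clear steps appear only against the 3-fluorophenyl and 3-methylphenyl compounds. Nothing available explains these steps.

The compounds shown leave open whether a 3-chlorophenyl group would stand with compound 3 or with compound 4, which would help separate the halogen from its position. An unsubstituted phenyl group or a 2-methylphenyl group would likewise show how much either feature contributes.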